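A Bromothiophene Replaces Hydroxyphenyl on Compound 1

A few compounds are considered here, and "the series" means these few. Any claim that something is new, unique, unknown or untested is made for them only; others in the source may bear on it.

Compound 1 `COc1ccc(-c2cc3ccccc3nc2/C=C/C(=O)c2ccc(O)cc2)cc1` gives the highest of the three numbers in a functional assay on NCI-H1299 cells (Homo sapiens) for antiproliferative activity, read by XTT assay, with a stated time of 72 h (on this read-out higher numbers stand for weaker inhibition and lower numbers for stronger inhibition), namely 8970 nM. Compound 2 `COc1ccc(-c2cc3ccccc3nc2/C=C/C(=O)c2ccc(N)cc2)cc1` gives 6510 nM in this assay, and compound 3 `COc1ccc(-c2cc3ccccc3nc2/C=C/C(=O)c2cccs2)cc1` gives 720 nM. Compound 4 `COc1ccc(-c2cc3ccccc3nc2/C=C/C(=O)c2ccc(Br)s2)cc1` differs from compound 1 as follows: 5-bromothiophen-2-yl in place of 4-hydroxyphenyl on a carbonyl carbon. The step that bears most on this change is a 12-fold lower number from compound 1 to compound 3 (1.10 log units; beyond the scatter); the related 9.0-fold lower number from compound 2 to compound 3 (0.96 log units; beyond the scatter) points the same way, while a 1.4-fold lower number from compound 1 to compound 2 (0.14 log units; within the scatter). Among the compounds with values here, no measured step includes 5-bromothiophen-2-yl itself. Compound 4 is therefore expected to show a step of about a 15-fold lower number from compound 1 to compound 4 (1.17 log units; beyond the scatter) in this assay, towards stronger inhibition. The estimated value for compound 4 in this assay is 600 nM, with a range from 150 nM to 2500 nM.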

Compound 4, half-maximal inhibitory concentration: 710 nM
The estimate for compound 4 lay 1.2-fold (0.07 log units) below the measured number; the measured number falls inside the stated range.
By their numbers in this assay, from the lowest: compounds 4 and 3 (each within the scatter of the next); then compounds 2 and 1 (each within the scatter of the next).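

Bromo in place of hydrogen on an aromatic carbon gives a 1.0-fold lower number from compound 3 to compound 4 (0.01 log units; within the scatter) in this assay and so leaves the number where it was, within the scatter. The gain at this carbonyl carbon therefore holds with the bromine present, as a 13-fold lower number from compound 1 to compound 4 (1.10 log units; beyond the scatter) and a 9.2-fold lower number from compound 2 to compound 4 (0.96 log units; beyond the scatter) both show for 5-bromothiophen-2-yl in place of 4-hydroxyphenyl and 4-aminophenyl. No measurement shown gives a reason for these steps. On these data alone, whether a methyl, an amine or a carboxylic acid in place of the bromo would leave the number equally undisturbed stays open.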